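Nitrile side chains in a sulfonamide series: permeability notes

This account rests on a few compounds, and the source may have more. Where it says the series, first, only, none or still open, it means among the compounds named here.

Measured so far in an ADME assay on MDCKII-LE cells (Canis lupus familiaris) for permeability; a lower number here means that the compound crosses the layer more slowly, a higher number that the compound crosses the layer faster:
- compound 1 `N#CC12CC(CN([C@H](CCC(F)(F)F)C(N)=O)S(=O)(=O)c3ccc(Cl)cc3)(C1)C2` gives 30.2 10^-6 cm/s
- compound 2 `N#CCCN([C@H](CCC(F)(F)F)C(N)=O)S(=O)(=O)c1ccc(Cl)cc1` gives 10.2 10^-6 cm/s
- compound 3 `N#C[C@H]1C[C@@H](CN([C@H](CCC(F)(F)F)C(N)=O)S(=O)(=O)c2ccc(Cl)cc2)C1` gives 24.1 10^-6 cm/s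

Compound 3, at 24.1 10^-6 cm/s, lies within the scatter of compound 1 and above compound 2. Compound 4 `C[C@]1(C#N)C[C@@H](CN([C@H](CCC(F)(F)F)C(N)=O)S(=O)(=O)c2ccc(Cl)cc2)C1` carries 3-cyano-3-methylcyclobutyl in place of 3-cyanocyclobutyl on a saturated chain carbon bound to a sulfonamide nitrogen. Among the measured compounds shown here, no measured step makes this exact change. The closest comparison is a 1.3-fold lower number from compound 1 to compound 3 (0.10 log units; within the scatter), whereas a 2.4-fold higher number from compound 2 to compound 3 (0.37 log units; beyond the scatter) and a 3.0-fold lower number from compound 1 to compound 2 (0.47 log units; beyond the scatter) involve the much smaller cyanomethyl-bearing compound 2. A step within the scatter is therefore expected, with no firm direction. The expected step in this assay is a 1.1-fold higher number from compound 3 to compound 4 (0.05 log units; within the scatter) for this change. Compound 4 is estimated at 27 10^-6 cm/s, with an expected range of 15 10^-6 cm/s to 45 10^-6 cm/s in this series.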

Compound 4, apparent permeability: 25.7 10^-6 cm/s
The estimate for compound 4 lay 1.1-fold (0.02 log units) above the measured number, and the stated range covers the measured number.
By their numbers in this assay, from the lowest: compound 2; then compounds 3, 4 and 1 (each within the scatter of the next).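

In this assay, 3-cyano-3-methylcyclobutyl in place of 3-cyanocyclobutyl gives a 1.1-fold higher number from compound 3 to compound 4 (0.03 log units; within the scatter) and so stays within the scatter, which shows that this position accepts the change without a clear shift in the read-out. Against the two-ring side chain of compound 1, the step is a 1.2-fold lower number from compound 1 to compound 4 (0.07 log units; within the scatter) and also stays within the scatter. The step of a 2.5-fold higher number from compound 2 to compound 4 (0.40 log units; beyond the scatter) lies beyond the scatter, and compound 2 alone remains apart from the other three.

On these data alone, whether an amine or a carboxylic acid in place of the nitrile on the cyclobutyl ring would keep the number in this range stays open. Nothing at hand gives a reason for these numbers.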